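A few compounds are considered here, and "the series" means these few. Any claim that something is new, unique, unknown or untested is made for them only; others in the source may bear on it.

Of the compounds shown here, two have been measured in a functional assay on HepG2 cells (Homo sapiens) for inhibition, read by MTT assay, with a stated time of 72 h; a higher number here means a weaker inhibitor, a lower number a stronger inhibitor. Compound 1 `O=C(OC1(C(=O)Nc2ccc([N+](=O)[O-])cc2)CCCCC1)c1ccc(Br)cc1` gives 284 nM, and compound 2 `CC(=O)OC1(C(=O)Nc2ccc([N+](=O)[O-])cc2)CCCCC1`, which carries a methyl in place of the 4-bromophenyl on the carbonyl carbon, gives 519 nM. The step in this assay a 1.8-fold higher number from compound 1 to compound 2 (0.26 log units; within the scatter) is within the scatter, so the two numbers cannot be told apart. For the measured compounds named here, of the two measured numbers, the one for compound 2 is the higher. Its gap to compound 1 is within the scatter, and the two compounds are not ranked here.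

The next step goes from compound 2 to compound 3 `O=C(Nc1ccc([N+](=O)[O-])cc1)C1(O)CCCCC1`, where the change is hydrogen in place of acetyl on an oxygen on a saturated carbon; cut one bond further out, it reads acetoxy to hydroxy. Going by the values given here, only the step from compound 1 to compound 2 bears on it, and that step was within the scatter. Shrinking the group on the carbonyl carbon left the number essentially unchanged, and removing the acetyl altogether moves outside what has been measured. The expected change in this assay is a 1.7-fold higher number from compound 2 to compound 3 (0.24 log units; within the scatter), leaning toward a higher number with wide uncertainty. Compound 3 is estimated to give 900 nM, with a range from 300 nM to 3000 nM.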

Compound 3, half-maximal inhibitory concentration: 648 nM
Compound 3: middle estimate off by 1.4-fold (0.14 log units), on the high side; low and high end bracket the measured number.
By their numbers in this assay, from the lowest: compounds 1, 2 and 3 (each within the scatter of the next, the first and the last beyond it).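

Taking the acetyl off the oxygen on the saturated carbon leaves the hydroxy group and gives a 1.2-fold higher number from compound 2 to compound 3 (0.10 log units; within the scatter) in this assay, so at this position the acetoxy and hydroxy compounds cannot be told apart. For the compounds shown here, the wider comparison, hydrogen in place of (4-bromophenyl)carbonyl on the same oxygen, gives a 2.3-fold higher number from compound 1 to compound 3 (0.36 log units; beyond the scatter) and is the first gap in this short series that lies beyond the scatter, although it is modest in size and compound 2 cannot be separated from either neighbour. The only readable difference at this oxygen therefore lies between the (4-bromophenyl)carbonyl group and hydrogen, and no separate measurement is available to account for it.

On these data alone, it remains open whether the bromine contributes to that modest gap, which a plain benzoyl group on the same oxygen would help to show, or whether the aromatic ring alone is enough. Also open, as far as these compounds go, is how the number would respond to a methyl ether on this oxygen, a longer chain on the carbonyl carbon, or an amine in place of the hydroxy group.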